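Adding a Methyl to the Ring Nitrogen of Compound 2

The compounds below may be only part of what the source reports. "The series", "measured", "known", "first", "only" and "open" are said of these compounds alone.

Compound 1, `COc1ccc(-c2nnc(-c3c[nH]c4ccccc34)o2)cc1OC`: in a functional assay on MIA PaCa-2 cells (Homo sapiens) for cytotoxicity, read by MTT assay (on this read-out higher numbers stand for weaker inhibition and lower numbers for stronger inhibition), compound 1 gives > 1000000 nM, which is a limit of the assay rather than a number.
Compound 2, `COc1cc(-c2nnc(-c3c[nH]c4ccccc34)o2)ccc1OCc1ccccc1`: in this assay compound 2 gives > 1000000 nM, again a limit of the assay.

Compound 2 therefore stands at the edge of what this assay can report, and the same holds for every value seen so far (the limit of > 1000000 nM in this assay, at which 2 of the 2 values shown sit). Among the measured compounds shown here, the one measured step, a step that the two limits leave unreadable from compound 1 to compound 2, cannot be sized because both of its ends are limits, so it gives no readable guide to how large a change any modification brings.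

The next step is methyl in place of hydrogen on an aromatic nitrogen, which turns compound 2 into compound 3, `COc1cc(-c2nnc(-c3cn(C)c4ccccc34)o2)ccc1OCc1ccccc1`. With no readable step to build on, the step from compound 2 to compound 3 is expected to stay within the scatter, as a number no higher from compound 2 to compound 3 (the limit leaves the size open). Compound 3 is accordingly estimated at 1000000 nM, in a range from 200000 nM to 5000000 nM, most likely reported again only as a limit.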

Compound 3, half-maximal inhibitory concentration: 1400 nM
The estimate for compound 3 lay 710-fold (2.85 log units) above the measured number; the measured number lies below the stated range.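

Among the compounds shown here, the change adds a single carbon, methyl in place of hydrogen on the aromatic nitrogen, yet it brings an at least 710-fold lower number from compound 2 to compound 3 (2.85 log units; beyond the scatter) in this assay, the first step in these compounds whose size can be read at all. This shows that the aromatic nitrogen is a place where a very small change can turn a compound with no measurable effect in this assay into one that gives a real number. The step has only a minimum size, since the value of compound 2 is a limit and not a number: the limit of > 1000000 nM in this assay, at which 2 of the 3 values shown sit.

With methyl as the only group shown on this nitrogen, it remains open whether an ethyl group, a longer chain or a chain ending in an amine would strengthen or lose this effect. As far as these compounds go, it also remains open whether methyl on the same nitrogen of compound 1 would bring a comparable step.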